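Amine substituent variation on the shared core: compound 4

A few compounds are considered here, and "the series" means these few. Any claim that something is new, unique, unknown or untested is made for them only; others in the source may bear on it.

In an assay on CHO cells for displacement of a labelled ligand from adenosine receptor A3 (Homo sapiens) (a lower number here means a stronger inhibitor, a higher number a weaker inhibitor), compound 1 `CCOC(=O)c1cnc(NC2CC2)n2nc(-c3ccco3)nc12` gives 9.52 nM. Compound 2 `CCOC(=O)c1cnc(NC2CCCC2)n2nc(-c3ccco3)nc12` gives 35 nM in this assay, and compound 3 `CCOC(=O)c1cnc(NCc2ccc(F)cc2)n2nc(-c3ccco3)nc12` gives 46.3 nM. Compound 3 thus holds the highest number of the three; its step to compound 2 lies within the scatter, while a 4.9-fold higher number from compound 1 to compound 3 (0.69 log units; beyond the scatter) and a 3.7-fold higher number from compound 1 to compound 2 (0.57 log units; beyond the scatter) are modest and beyond the scatter.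

Compound 4 `CCOC(=O)c1cnc(N(C)C)n2nc(-c3ccco3)nc12` differs from compound 3 in one place: dimethylamino in place of (4-fluorobenzyl)amino on an aromatic carbon. Among the measured compounds shown here, none of the measured steps removes the hydrogen-bond donor on that nitrogen, so the closest guides are the swaps of the group on that nitrogen, which moved this assay by a 3.7-fold higher number from compound 1 to compound 2 (0.57 log units; beyond the scatter) and a 4.9-fold higher number from compound 1 to compound 3 (0.69 log units; beyond the scatter), with a 1.3-fold higher number from compound 2 to compound 3 (0.12 log units; within the scatter) within the scatter. For the measured compounds named here, the smallest group on that nitrogen, in compound 1, carries the lowest number, but dimethylamino is a different kind of group and no direct precedent exists.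

A modest step, probably toward a lower number, is expected for compound 4 with wide uncertainty; the estimated step is a 1.5-fold lower number from compound 3 to compound 4 (0.19 log units; within the scatter). Compound 4 is therefore estimated at 30 nM in this assay, with a range from 8 nM to 120 nM.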

Compound 4, inhibition constant: 275 nM
Compound 4: middle estimate off by 9.2-fold (0.96 log units), on the low side, and the stated range ends below it.
By their numbers in this assay, from the lowest: compound 1; then compounds 2 and 3 (each within the scatter of the next); then compound 4.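

Compound 4 is the only compound shown whose group on that nitrogen, dimethylamino, has 0 hydrogen-bond donors, and in this assay it sits apart from all three others, with a 5.9-fold higher number from compound 3 to compound 4 (0.77 log units; beyond the scatter) and a 7.9-fold higher number from compound 2 to compound 4 (0.90 log units; beyond the scatter) and also a 29-fold higher number from compound 1 to compound 4 (1.46 log units; beyond the scatter) on this core. Small size alone therefore does not give a low number at this position: dimethylamino, with 3 heavy atoms, is smaller than the (4-fluorobenzyl)amino group with 9 heavy atoms, yet compound 4 carries the higher number, so compound 4 goes against the reading suggested by compound 1 alone. No measurement available here accounts for this loss, so the link with the missing hydrogen-bond donor remains a correlation resting on a single compound.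

The compounds shown leave open whether the step follows from losing the hydrogen on that nitrogen or from the particular pair of methyl groups, since both changes arrive together in compound 4. Methylamino, unsubstituted amino and methyl(cyclopropyl)amino on the same core would pull these two changes apart, and a ring amine such as pyrrolidine would show whether other groups without that hydrogen follow compound 4.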